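The source may report more compounds than this note shows. Statements on the series, on what has been measured and on what is new or still open speak of the compounds shown alone.

Measured compounds:
compound 1 `COc1ccc(/C=C/C(O)=C/C(=O)/C=C/C2=C(C)CCCC2(C)C)cn1`, in a functional assay on LNCaP C4-2B cells (Homo sapiens) for cytotoxicity, read by MTT assay, with a stated time of 72 h (on this read-out higher numbers stand for weaker inhibition and lower numbers for stronger inhibition), compound 1 gives "not determined" (no result reported);
compound 2 `CC1=C(/C=C/C(=O)/C(=C\c2ccc(O)cc2)C(=O)/C=C/c2ccc(O)cc2)C(C)(C)CCC1`, in this assay compound 2 gives 4000 nM.

Compound 1 has no single number to stand on: its result in this assay was not determined, so nothing here shows how it compares with compound 2. Compound 3 `COc1cc(/C=C/C(O)=C/C(=O)/C=C/C2=C(C)CCCC2(C)C)ccc1O` is not yet measured. It differs from compound 1 in one place: 4-hydroxy-3-methoxyphenyl in place of 6-methoxypyridin-3-yl on a double-bonded chain carbon bound to a double-bonded chain carbon. For the measured compounds named here, without a value for compound 1, no measured step frames this change, and compound 2 offers only a distant point of reference for the shared core. Any step from compound 1 to compound 3 in this assay is expected to be small, with no clear direction beyond the usual scatter. On that basis compound 3 is estimated to give about 8000 nM in this assay, with a likely range from 2500 nM to 25000 nM.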

Compound 3, half-maximal inhibitory concentration: 44300 nM
Compound 3: the middle estimate sits 5.5-fold (0.74 log units) below what was measured; the measured number lies above the stated range.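

In this assay, for the compounds shown here, compound 1 gives "not determined" (no result reported), so no step from compound 1 to compound 3 can be read. On these data alone, the effect of exchanging 6-methoxypyridin-3-yl for 4-hydroxy-3-methoxyphenyl therefore remains open. No available evidence bears on the result for compound 3.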